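The compounds below may be only part of what the source reports. "The series", "measured", "known", "first", "only" and "open" are said of these compounds alone.

In an ADME assay on L1210/0 cells (Mus musculus) for cytotoxicity, with a stated time of 48 h (on this read-out higher numbers stand for weaker inhibition and lower numbers for stronger inhibition), three compounds built on one shared core have been measured. Compound 1 `COc1ccc(-c2ncnc3c2ncn3C[C@@H]2C[C@H](CO)c3ccccc32)cc1`, which carries 4-methoxyphenyl, gives 17600 nM. Compound 2 `CCCNc1ncnc2c1ncn2C[C@@H]1C[C@H](CO)c2ccccc21`, which carries propylamino, gives only a limit of the assay, > 200000 nM. Compound 3 `Nc1ncnc2c1ncn2C[C@@H]1C[C@H](CO)c2ccccc21`, which carries amino, also gives only a limit, > 200000 nM. Compound 3 therefore stands at the limit of > 200000 nM in this assay, at which 2 of the 3 values shown sit.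

Compound 4 `CCOc1ncnc2c1ncn2C[C@@H]1C[C@H](CO)c2ccccc21` has ethoxy in place of amino on an aromatic carbon. Two measured changes at this carbon bear on it: an at least 11-fold higher number from compound 1 to compound 2 (1.05 log units; beyond the scatter), and an at least 11-fold higher number from compound 1 to compound 3 (1.05 log units; beyond the scatter). Both are large, and only compound 1, with its 4-methoxyphenyl, gives a true number. The third comparison is a step that the two limits leave unreadable from compound 2 to compound 3. Ethoxy, like amino, has no ring, so compound 4 is expected to stay close to compound 3, with no step beyond the scatter in this assay. The estimated step is an at least 1.3-fold lower number from compound 3 to compound 4 (0.12 log units; that floor lies within the scatter). For compound 4, the estimated value is 150000 nM, with an expected range from 50000 nM to 300000 nM.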

Compound 4, half-maximal inhibitory concentration: > 200000 nM
Compound 4: no number, only a limit (the forecaster's own chance of this, stated with the estimate: 55%); middle value at least 1.3-fold (0.12 log units) from the limit.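

With ethoxy, a group joined through oxygen behaves like the two nitrogen-linked groups: replacing 4-methoxyphenyl with ethoxy gives an at least 11-fold higher number from compound 1 to compound 4 (1.05 log units; beyond the scatter). In this assay, the steps from compound 4 to compounds 2 and 3 cannot be read, since each pair has only limits of the assay at both ends. At this aromatic carbon, compound 1 alone now gives a true number, while the three compounds without a ring there share one limit: the limit of > 200000 nM in this assay, at which 3 of the 4 values shown sit.

The compounds shown leave open how far past that limit compounds 2, 3 and 4 lie, and so whether they differ from one another. They also leave open whether the ring alone goes with the lower number in compound 1, which a plain phenyl at this carbon, without the methoxy, would test.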